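A few compounds are considered here, and "the series" means these few. Any claim that something is new, unique, unknown or untested is made for them only; others in the source may bear on it.

Measured so far in this series:

Compound 1, `c1ccc2c(c1)CC(CCCN1CCN(c3cccc4c3OCCO4)CC1)C2`: 1.73 mg/kg
Compound 2, `c1ccc2c(c1)CC2CCCN1CCN(c2cccc3c2OCCO3)CC1`: 0.45 mg/kg
Compound 3, `c1ccc2c(c1)CC2CN1CCN(c2cccc3c2OCCCO3)CC1`: < 2.5 mg/kg (a limit of the assay, not a number)

In an assay for activation of Adrenergic receptor alpha-1 (Rattus norvegicus) (a lower number here means that less compound is needed, a higher number that more compound is needed for the effect), compound 2 gives 0.45 mg/kg, the lowest of the two numbers shown. Going by the values given here, its nearest neighbour is compound 1, and the only measured step runs a 3.8-fold lower number from compound 1 to compound 2 (0.58 log units; beyond the scatter). Compound 3 sits at the limit of < 2.5 mg/kg in this assay, at which 1 of the 3 values shown sits, which is a limit of the assay and not a number.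

Compound 4, `c1ccc2c(c1)CC(CCN1CCN(c3cccc4c3OCCO4)CC1)C2`, has not yet been measured. It differs from compound 2 in one place: a group of 9 heavy atoms (9 carbon; one five-membered non-aromatic ring of carbon only, one six-membered aromatic ring of carbon only) in place of a group of 9 heavy atoms (9 carbon; one four-membered non-aromatic ring of carbon only, one six-membered aromatic ring of carbon only), on a saturated chain carbon, two bonds along the chain from an amine nitrogen in a ring. Among the compounds with values here, the one step that bears on this change is a 3.8-fold lower number from compound 1 to compound 2 (0.58 log units; beyond the scatter), in which the same two ring systems were swapped the other way round, though at a different place on the chain. Since compound 4 carries back the ring system of compound 1, a modest rise in this assay is expected, a 2.7-fold higher number from compound 2 to compound 4 (0.43 log units; beyond the scatter), smaller than the measured step because a 3.8-fold lower number from compound 1 to compound 2 (0.58 log units; beyond the scatter) was measured three bonds along the chain from the amine nitrogen, whereas compound 4 carries the change two bonds along the chain. Compound 4 is therefore estimated at 1.2 mg/kg, with a likely range from 0.4 mg/kg to 3.5 mg/kg.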

Compound 4, dose for half-maximal effect: 0.66 mg/kg
Compound 4: middle estimate off by 1.8-fold (0.26 log units), on the high side; measured number inside the range.
By their numbers in this assay, from the lowest: compounds 2 and 4 (each within the scatter of the next); then compound 1.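

In this assay, the swap of ring systems gives a 1.5-fold higher number from compound 2 to compound 4 (0.17 log units; within the scatter) at this place, two bonds along the chain from an amine nitrogen in a ring, so the 2,3-dihydro-1H-inden-2-yl group and the four-membered ring group cannot be told apart here. The same two ring systems did separate at three bonds along the chain, where the result was a 3.8-fold lower number from compound 1 to compound 2 (0.58 log units; beyond the scatter) and so the effect of this change is not the same at both places, though each place rests on a single pair. Nothing measured here explains that contrast.

On these data alone, it remains open whether a ring carrying an amine or a carboxylic acid would move the number at this place. A chain longer than those in compound 1 and compound 2 is also untested among the compounds shown.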